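Solubility notes on the urea series: compound 1 to compound 4

The source may hold more compounds than are shown below. What is called first, only, known or untested is meant among the compounds shown, and "the series" means these compounds.

Measured compounds:
compound 1 `Cc1cc(NC(=O)Nc2ccccc2OC(F)(F)F)c2ccccc2n1` — 4600 nM
compound 2 `Cc1cc(NC(=O)Nc2ccc(Cl)c(Cl)c2)c2ccccc2n1` — 300 nM
compound 3 `CC(=O)c1ccc(NC(=O)Nc2cc(C)nc3ccccc23)cc1` — 3800 nM

In a physicochemical assay for solubility, at pH 7.4 (on this read-out higher numbers stand for higher solubility and lower numbers for lower solubility), compound 1 gives 4600 nM, the highest of the three numbers. Compound 3, with 3800 nM, sits so close to it that the two cannot be told apart; the gap lies within the usual scatter of this assay. Compound 2, at 300 nM, stands clearly below compound 1, a gap well beyond the scatter.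

The next compound, compound 4 `CSc1ccccc1NC(=O)Nc1cc(C)nc2ccccc12`, differs from compound 1 in a single place: methylsulfanyl in place of trifluoromethoxy on an aromatic carbon. Within the data shown here, no pair of measured compounds shows this same change, so there is no measured step in this assay from which its size could be read directly. The three measured values only show that the shared core tolerates very different numbers depending on the substituents of the second ring.

The step from compound 1 in this assay, a 1.1-fold higher number from compound 1 to compound 4 (0.04 log units; within the scatter), is expected to be small and most likely not beyond the scatter. Compound 4 is therefore expected to give about 5000 nM in this assay, with a range of 2000 nM to 13000 nM.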

Compound 4, solubility: 21000 nM
Estimate against measurement, compound 4: 4.2-fold (0.62 log units) below; measured number above the stated range.
By their numbers in this assay, from the lowest: compound 2; then compounds 3 and 1 (each within the scatter of the next); then compound 4.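

In this assay, among these compounds, methylsulfanyl in place of trifluoromethoxy on an aromatic carbon, ortho to a large group, gives the first step between compounds that differ in one place: a 4.6-fold higher number from compound 1 to compound 4 (0.66 log units; beyond the scatter). The number at this position therefore depends on which group it carries, even though the two groups match in having no ring, no net charge, 0 hydrogen-bond donors and 1 hydrogen-bond acceptor, and differ in heavy atoms, with 5 leaving and 2 entering. No measurement in hand bears on why the number moves, and this single pair describes one change at one place rather than a trend.

The compounds shown leave open whether the step follows the sulfur atom or the smaller heavy-atom count, a question that methoxy or methyl on the same carbon would help to separate. Also open, from the compounds shown here alone, are how an amine or a carboxylic acid would read there, and whether the same exchange on another aromatic carbon would give a step of similar size.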